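The compounds below may be only part of what the source reports. "The series", "measured", "known", "first", "only" and "open" are said of these compounds alone.

Measured compounds:
- compound 1 `O=C1Nc2ccccc2C1(c1c(-c2ccccc2)[nH]c2ccccc12)c1c(-c2ccccc2)[nH]c2ccccc12`: 9600 nM in a functional assay on SK-N-SH cells (Homo sapiens) for cytotoxicity, read by MTT assay, with a stated time of 48 h; on this read-out higher numbers stand for weaker inhibition and lower numbers for stronger inhibition
- compound 2 `O=C1Nc2ccc(Cl)cc2C1(c1c[nH]c2ccc(Br)cc12)c1c[nH]c2ccc(Br)cc12`: 1040 nM in this assay
- compound 3 `O=C1Nc2ccc(Cl)cc2C1(c1c(-c2ccccc2)[nH]c2ccccc12)c1c(-c2ccccc2)[nH]c2ccccc12`: > 100000 nM in this assay, which is a limit of the assay and not a number

Compound 1 and compound 3 differ in one place only: hydrogen in place of chloro on an aromatic carbon. This single change gave an at least 10-fold lower number from compound 3 to compound 1 (1.01 log units; beyond the scatter), so taking the chloro away went with a markedly lower number, though the size of that step is only a lower bound, as it starts from a limit. Compound 2 gives a number below that of compound 1, and the step between them lies beyond the usual scatter. How the core of compound 2 differs from that of compound 3 is not broken down here.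

Compound 4 `O=C1Nc2ccccc2C1(c1c[nH]c2ccc(Br)cc12)c1c[nH]c2ccc(Br)cc12` has not yet been measured. It relates to compound 2 exactly as compound 1 relates to compound 3: hydrogen in place of chloro on an aromatic carbon. The place of the change is the same in both pairs, so this is the same change made on a different core. Resting on the step of an at least 10-fold lower number from compound 3 to compound 1 (1.01 log units; beyond the scatter), the number for compound 4 is expected to come out lower than that of compound 2, by an estimated 3.0-fold lower number from compound 2 to compound 4 (0.47 log units; beyond the scatter) in this assay. The earlier step was measured from a limit, and its true size is not known. A single example is also a thin basis. The expected step is set smaller than that bound. The estimate for compound 4 is 350 nM, with a likely range from 80 nM to 1500 nM.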

Compound 4, half-maximal inhibitory concentration: 930 nM
Compound 4: the middle estimate sits 2.7-fold (0.42 log units) below what was measured; the range from low to high includes it.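

Putting hydrogen in place of chloro on the core of compound 2 gives a 1.1-fold lower number from compound 2 to compound 4 (0.05 log units; within the scatter) in this assay, so on this core the change has no effect that can be told apart from the usual scatter of the measurement. The same change therefore does not carry over in size from one core to the other, and what it does on one core in this series cannot simply be assumed for the other: the same change on two cores in this assay, an at least 10-fold lower number (1.01 log units; beyond the scatter) from compound 3 to compound 1 and a 1.1-fold lower number (0.05 log units; within the scatter) from compound 2 to compound 4, at least 9.3-fold (0.96 log units) apart, beyond the scatter of two such steps

Compound 3 gives > 100000 nM, which is a limit of the assay and not a number, so the true size of the larger step stays unknown, and with only one pair on each core the data do not show which feature of the cores sets the difference: the limit of > 100000 nM in this assay, at which 1 of the 4 values shown sits.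

The compounds shown carry only hydrogen or chloro at this place, so what a fluoro group, a methoxy group, an amine or a carboxylic acid would do there remains open. Also open, from the compounds shown here alone, is how the change would behave on any further core, as two cores, which disagree with each other, set no rule for the series.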